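A Secondary Amine in Place of Piperidin-1-yl

The source may hold more compounds than are shown below. What is called first, only, known or untested is meant among the compounds shown, and "the series" means these compounds.

Measured compounds:
Compound 1 `CC(C)=CCc1cc(C(=O)Nc2cc3ccc(OCC4CCCN(C)C4)c(C)c3oc2=O)ccc1O` gives 2640 nM in a functional assay on MCF7 cells (Homo sapiens) for antiproliferative activity; a higher number here means a weaker inhibitor, a lower number a stronger inhibitor.
Compound 2 `CC(C)=CCc1cc(C(=O)Nc2cc3ccc(OCCCN4CCCCC4)c(C)c3oc2=O)ccc1O` gives only a limit of the assay, > 50000 nM.
Compound 3 `CC(C)=CCc1cc(C(=O)Nc2cc3ccc(OCCCNCC(C)C)c(C)c3oc2=O)ccc1O` gives 1320 nM.

Compound 2 therefore stands at the limit, (the limit of > 50000 nM in this assay, at which 1 of the 3 values shown sits), with no number of its own. Compound 4 `COC(=O)CNCCCOc1ccc2cc(NC(=O)c3ccc(O)c(CC=C(C)C)c3)c(=O)oc2c1C` differs from it in one place: ((methoxycarbonyl)methyl)amino in place of piperidin-1-yl on a saturated chain carbon, three bonds along the chain from an oxygen on an aromatic ring. The step that bears most directly on this change is an at least 37-fold lower number from compound 2 to compound 3 (1.57 log units; beyond the scatter), which swaps the same piperidin-1-yl for another amino group at the same place; an at least 18-fold higher number from compound 1 to compound 2 (1.27 log units; beyond the scatter) also shows the piperidin-1-yl compound far behind. A large step to a lower number is therefore expected, an at least 12-fold lower number from compound 2 to compound 4 (1.09 log units; beyond the scatter). Compound 4 is estimated at 4000 nM, in the range 1000 nM to 20000 nM.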

Compound 4, half-maximal inhibitory concentration: 2820 nM
Beside the measured number, compound 4's estimate is 1.4-fold (0.15 log units) above it, and the stated range covers the measured number.
By their numbers in this assay, from the lowest: compounds 3, 1 and 4 (each within the scatter of the next, the first and the last beyond it). At a limit, above all of these: compound 2.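

In this assay, a second open-chain amino group at this place also stands far ahead of piperidin-1-yl (an at least 17-fold lower number from compound 2 to compound 4 (1.24 log units; beyond the scatter)), so the large step is not peculiar to isobutylamino. Methoxycarbonyl in place of isopropyl on that chain changes the number only modestly (a 2.1-fold higher number from compound 3 to compound 4 (0.33 log units; beyond the scatter)), and the result stays level with the 1-methylpiperidin-3-yl compound (a 1.1-fold higher number from compound 1 to compound 4 (0.03 log units; within the scatter)). Compound 2 still has no number of its own, only a limit: the limit of > 50000 nM in this assay, at which 1 of the 4 values shown sits.

From the compounds shown here alone, how a carboxylic acid in place of the methyl ester would read stays open. So does how a morpholine or a dimethylamino group would compare with piperidin-1-yl on this chain.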